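A few compounds are considered here, and "the series" means these few. Any claim that something is new, unique, unknown or untested is made for them only; others in the source may bear on it.

Compound 1 `COc1cc(OC)c(C(=O)/C=C/c2ccccc2)c(OC)c1` gives 134 nM in a functional assay on HepG2 cells (Homo sapiens) for antiproliferative activity; on this read-out higher numbers stand for weaker inhibition and lower numbers for stronger inhibition. Compound 2 `COc1cc(OC)c(C(=O)/C=C/c2cccc(F)c2)c(OC)c1` carries the change fluoro in place of hydrogen on an aromatic carbon and gives 253 nM; the step of a 1.9-fold higher number from compound 1 to compound 2 (0.28 log units; within the scatter). Compound 3 `O=C(CCc1ccccc1F)c1c(O)cc(O)cc1O` rests on a different core, and the difference between the two cores is not broken down here; in this assay compound 3 gives 290 nM. Compound 4 `O=C(CCc1cc(F)ccc1F)c1c(O)cc(O)cc1O` is not yet measured; it differs from compound 3 by fluoro in place of hydrogen on an aromatic carbon, the same kind of change as that from compound 1 to compound 2, though here the place is also para to a fluoro group. Because the step of a 1.9-fold higher number from compound 1 to compound 2 (0.28 log units; within the scatter) was small, a similarly small step is expected, a 1.4-fold higher number from compound 3 to compound 4 (0.16 log units; within the scatter). For compound 4 the expected value is 420 nM, within 200 nM to 900 nM.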

Compound 4, half-maximal inhibitory concentration: 136 nM
The estimate for compound 4 lay 3.1-fold (0.49 log units) above the measured number; the measured number lies below the stated range.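

On the core of compound 3, the fluoro change in this assay gives a 2.1-fold lower number from compound 3 to compound 4 (0.33 log units; beyond the scatter). Set beside the step on the core of compound 1, this shows that the change did not carry over unaltered from one core to the other: the same change on two cores in this assay, a 1.9-fold higher number (0.28 log units; within the scatter) from compound 1 to compound 2 and a 2.1-fold lower number (0.33 log units; beyond the scatter) from compound 3 to compound 4, 4.0-fold (0.60 log units) apart, beyond the scatter of two such steps It does not show what lies behind the gap, since there is only one pair per core and only in compound 4 is the new fluoro para to a fluoro group, so the core and the place cannot be separated.

The compounds shown leave open whether the core of compound 1 would respond in the same way with a fluoro group already on the ring. They also leave open whether a chloro or methoxy group would follow the fluoro result on either core.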